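A few compounds are considered here, and "the series" means these few. Any claim that something is new, unique, unknown or untested is made for them only; others in the source may bear on it.

Measured so far in a functional assay on HEK293 cells with D(4) dopamine receptor (Homo sapiens) as the target, read by FLIPR; on this read-out higher numbers stand for larger maximal responses and lower numbers for smaller maximal responses:
- compound 1 `O/N=C(/CCN1CCN(c2ccccn2)CC1)c1ccccc1` gives 74%
- compound 2 `O/N=C(/CCN1CCN(c2ccccn2)CC1)c1ccccc1Cl` gives 64%
- compound 3 `Cc1ccccc1/C(CCN1CCN(c2ccccn2)CC1)=N\O` gives 72%

Of these three numbers, compound 1 carries the largest, but the steps of a number 2 percentage points lower from compound 1 to compound 3 (within the scatter) and a number 10 percentage points lower from compound 1 to compound 2 (within the scatter) both stay within the scatter, as does a number 8 percentage points higher from compound 2 to compound 3 (within the scatter). All three measured steps concern the aromatic ring attached to the oxime carbon; none of them touches the group on the amine nitrogen in the ring.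

Compound 4 `O/N=C(/CCN1CCN(c2ncccn2)CC1)c1ccccc1` is the unmeasured compound. It differs from compound 1 in pyrimidin-2-yl in place of pyridin-2-yl on an amine nitrogen in a ring. Among the compounds with values here, no measured step bears on this change, so there is no direct guide to its effect in this assay. The three measured compounds, which vary only at the aromatic ring on the oxime carbon, all fall within the scatter of one another, which gives no hint that the shared core is sensitive to small changes at all. Compound 4 is therefore expected to give 70%, within 55% to 85%. This estimate means a step of a number 4 percentage points lower from compound 1 to compound 4 (within the scatter), expected to be no larger than the scatter.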

Compound 4, largest response reached (reported as efficacy), in percent of the reference or control that the assay uses: 52%
Compound 4: the middle estimate sits 18 percentage points above what was measured, and the stated range ends above it.
By their numbers in this assay, from the lowest: compound 4; then compounds 2, 3 and 1 (each within the scatter of the next).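

In this assay, the group on the amine nitrogen in the ring proves to matter: pyrimidin-2-yl in place of pyridin-2-yl gives a number 22 percentage points lower from compound 1 to compound 4 (beyond the scatter), whereas the chloro and methyl changes on the aromatic ring attached to the oxime carbon all stayed within the scatter. The two groups have the same number of heavy atoms and differ in one ring carbon being replaced by a nitrogen, so an exchange of a single ring atom at this position is enough to produce a step beyond the scatter. The data at hand offer no measurement that would explain this step.

As far as these compounds go, it remains open whether a phenyl or a pyridin-3-yl group on this nitrogen would behave like pyridin-2-yl or like pyrimidin-2-yl. From the compounds shown here alone, it is also open whether the step would persist with chloro or methyl on the aromatic ring.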